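Acyl variation on the cyclohexyl amide tail: tolerability

A few compounds are considered here, and "the series" means these few. Any claim that something is new, unique, unknown or untested is made for them only; others in the source may bear on it.

Compound 1 `CC(C)(C)C(=O)N(CCCCCCN1C[C@H](O)[C@@H](O)[C@H](O)[C@H]1CO)C1CCCCC1` and compound 2 `O=C(c1ccccc1)N(CCCCCCN1C[C@H](O)[C@@H](O)[C@H](O)[C@H]1CO)C1CCCCC1` share the same core and differ only at the carbonyl. In an ADME assay on Huh-7 cells (Homo sapiens) for cytotoxicity, read by MTT assay (a higher number here means that more compound is tolerated, a lower number that less compound is tolerated), compound 1 gives 500000 nM. For compound 2 this assay reports only a limit, > 500000 nM. The step of a number no lower from compound 1 to compound 2 (the limit leaves the size open) therefore cannot be sized, and the limit of > 500000 nM in this assay, at which 1 of the 2 values shown sits, is all that is known for compound 2. Compound 3 `O=C(c1cc(F)c(F)cc1F)N(CCCCCCN1C[C@H](O)[C@@H](O)[C@H](O)[C@H]1CO)C1CCCCC1` extends this line: 2,4,5-trifluorophenyl in place of phenyl on a carbonyl carbon. For the measured compounds named here, of the measured steps only the one from compound 1 to compound 2 touches the acyl part, and that step stayed at the limit, so no measured step shows a loss of tolerability with a change at this carbonyl. The expected step from compound 2 to compound 3 is a number no higher from compound 2 to compound 3 (the limit leaves the size open), that is, none beyond the scatter, because the step of a number no lower from compound 1 to compound 2 (the limit leaves the size open) showed no loss. Compound 3 is estimated at 500000 nM in this assay, within a range of 200000 nM to 1000000 nM, and a reading that is again only a limit is likely.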

Compound 3, half-maximal cytotoxic concentration: > 500000 nM
Compound 3: a limit, no number (the forecaster's own chance of this, stated with the estimate: 60%); the middle value lies on the limit itself.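

In this assay compound 3 gives > 500000 nM, which is a limit and not a number, so a second aryl group on the carbonyl carbon, now 2,4,5-trifluorophenyl, ends at a limit as phenyl did. Against the tert-butyl amide the reading is a number no lower from compound 1 to compound 3 (the limit leaves the size open), whereas the step from compound 2 to compound 3 cannot be read, as both ends are limits. Adding three fluorine atoms to the phenyl ring therefore reveals no loss of tolerability at this carbonyl, and the series now collects at one value: the limit of > 500000 nM in this assay, at which 2 of the 3 values shown sit.

From the compounds shown here alone, how compound 2 and compound 3 rank against each other stays open. Also open, going by these compounds, is whether an amine or a carboxylic acid on the aryl ring, or a longer chain on the carbonyl carbon, would give a number rather than a limit.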